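This account rests on a few compounds, and the source may have more. Where it says the series, first, only, none or still open, it means among the compounds named here.

Measured in an ADME assay on 184B5 cells (Homo sapiens) for antiproliferative activity, read by sulforhodamine B assay, with a stated time of 72 h; a lower number here means a stronger inhibitor, a higher number a weaker inhibitor:

Compound 1 `FC(F)(F)c1ccc(/C=C\c2cc3ccccc3nc2Cl)cc1`: 7940 nM
Compound 2 `FC(F)(F)c1ccc(/C=C\c2cc3ccc(Cl)cc3nc2Cl)cc1`: 26400 nM
Compound 3 `FC(F)(F)c1cc(/C=C\c2cc3ccccc3nc2Cl)cc(C(F)(F)F)c1`: 13700 nM

Compound 2 differs from compound 1 by chloro in place of hydrogen on an aromatic carbon; this gave a 3.3-fold higher number from compound 1 to compound 2 (0.52 log units; beyond the scatter). How the core of compound 3 differs from that of compound 1 is not broken down here; the two values sit within the scatter of each other, as do those of compound 3 and compound 2.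

Compound 4 `FC(F)(F)c1cc(/C=C\c2cc3ccc(Cl)cc3nc2Cl)cc(C(F)(F)F)c1` is not yet measured. It differs from compound 3 by chloro in place of hydrogen on an aromatic carbon, the same change as that from compound 1 to compound 2, at the same place. In this assay, among the compounds with values here, a step of a 3.3-fold higher number from compound 3 to compound 4 (0.52 log units; beyond the scatter) is expected, resting on the single earlier instance, a 3.3-fold higher number from compound 1 to compound 2 (0.52 log units; beyond the scatter), applied to compound 3 with its 13700 nM. The estimate for compound 4 is therefore 45000 nM, expected between 20000 nM and 100000 nM.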

Compound 4, half-maximal inhibitory concentration: 43000 nM
Compound 4: middle estimate off by 1.0-fold (0.02 log units), on the high side; low and high end bracket the measured number.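

In this assay, chloro in place of hydrogen on an aromatic carbon gives a 3.1-fold higher number from compound 3 to compound 4 (0.50 log units; beyond the scatter), and the step keeps its direction and size from one core to the other: the same change on two cores in this assay, a 3.3-fold higher number (0.52 log units; beyond the scatter) from compound 1 to compound 2 and a 3.1-fold higher number (0.50 log units; beyond the scatter) from compound 3 to compound 4, 1.1-fold (0.03 log units) apart, within the scatter of two such steps. Within this series, the change can therefore be carried between these two cores at this one place. Within the data shown here, with only two pairs, this does not show that the step holds on any further core, and it gives no reason why the number rises.

Still open, going by these compounds, is whether another group at the same place, such as methoxy, nitrile or an amine, moves the number the same way. Also open, on these data alone, is whether the chloro step persists with an amine in place of trifluoromethyl.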